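The source may report more compounds than this note shows. Statements on the series, on what has been measured and on what is new or still open speak of the compounds shown alone.

Measured so far in an assay on tissue (HeLa cells) for inhibition of Indoleamine 2,3-dioxygenase 1 (Homo sapiens), with stated times of 2 h and 18 h; on this read-out higher numbers stand for weaker inhibition and lower numbers for stronger inhibition:
compound 1 `C[C@@H](C(=O)NC1CCCCC1)[C@H]1CC[C@@H](c2ccnc3ccc(F)cc32)CC1` gives 18 nM
compound 2 `C[C@@H](CNc1ccc(Cl)cc1)[C@H]1CC[C@@H](c2ccnc3ccc(F)cc32)CC1` gives 7 nM
compound 3 `C[C@@H](NCc1ccc(Cl)cc1)[C@H]1CC[C@@H](c2ccnc3ccc(F)cc32)CC1` gives 745 nM

Compound 3 stands highest of the three numbers: a 41-fold higher number from compound 1 to compound 3 (1.62 log units; beyond the scatter), and a 110-fold higher number from compound 2 to compound 3 (2.03 log units; beyond the scatter). The other measured step was far smaller: a 2.6-fold lower number from compound 1 to compound 2 (0.41 log units; beyond the scatter). Compound 4 `C[C@@H](NC(=O)Nc1ccc(Cl)cc1)[C@H]1CC[C@@H](c2ccnc3ccc(F)cc32)CC1` is the next member; relative to compound 3 the change is (4-chlorophenyl)carbamoyl in place of 4-chlorobenzyl on an amine nitrogen. The two steps that bear on it are the two into compound 3, both large, and both run from a group holding either a carbonyl (the cyclohexylcarbamoyl of compound 1) or a (4-chlorophenyl)amino element (compound 2) to the (4-chlorobenzyl)amino of compound 3. The entering (4-chlorophenyl)carbamoyl of compound 4 brings back both elements, so a large step downward in this assay is expected, a 37-fold lower number from compound 3 to compound 4 (1.57 log units; beyond the scatter), because a 41-fold higher number from compound 1 to compound 3 (1.62 log units; beyond the scatter) and a 110-fold higher number from compound 2 to compound 3 (2.03 log units; beyond the scatter) were both large. Among the measured compounds shown here, no measured pair tells whether the return goes all the way. Compound 4 is therefore estimated at 20 nM, with a range of 5 nM to 90 nM.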

Compound 4, half-maximal inhibitory concentration: 20 nM
Beside the measured number, compound 4's estimate shows no gap at the digits printed, within the range that was stated.
By their numbers in this assay, from the lowest: compound 2; then compounds 1 and 4 (each within the scatter of the next); then compound 3.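

In this assay, among the compounds shown here, the exchange of 4-chlorobenzyl for (4-chlorophenyl)carbamoyl on the amine nitrogen gives a 37-fold lower number from compound 3 to compound 4 (1.57 log units; beyond the scatter) and so shows that a nitrogen on this saturated chain carbon is compatible with a low number, which compound 3, the only earlier compound with that attachment, could not show. The entering group keeps the chlorine and the six-membered aromatic ring of carbon only, so the step is tied to the atoms linking that ring to the amine nitrogen, not to the ring or the chlorine. No measurement at hand explains why this link matters so much.

Still open, going by these compounds, is whether the carbonyl or the added nitrogen carries the step, a question that 4-chlorobenzoyl on the amine nitrogen would address. Also open, on these data alone, is how the series responds to fluorine or methoxy in place of the chlorine.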